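An Ester in Place of a Sulfonamide: Cytotoxicity Outlook

The compounds below may be only part of what the source reports. "The series", "measured", "known", "first", "only" and "open" are said of these compounds alone.

Compound 1 `CS(=O)(=O)NC1CCC(CN2CCN(c3cc(=O)c4cc(C(F)(F)F)cc([N+](=O)[O-])c4s3)CC2)CC1` gives 48.5 ug/mL in an ADME assay on Vero cells (Chlorocebus sabaeus) for cytotoxicity, read by MTT assay, with a stated time of 48 h; on this read-out lower numbers stand for stronger inhibition and higher numbers for weaker inhibition.
Compound 2 `O=C(OC1CCC(CN2CCN(c3cc(=O)c4cc(C(F)(F)F)cc([N+](=O)[O-])c4s3)CC2)CC1)c1ccc2ccccc2c1` gives > 64 ug/mL in this assay, which is a limit.
Compound 3 `O=C(OC1CCC(CN2CCN(c3cc(=O)c4cc(C(F)(F)F)cc([N+](=O)[O-])c4s3)CC2)CC1)c1cccc(C(F)(F)F)c1` gives > 64 ug/mL in this assay, also a limit.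

Compound 1 stands alone as the only one of the three with an actual number; the other two sit at the limit of > 64 ug/mL in this assay, at which 2 of the 3 values shown sit. For the measured compounds named here, the one single-point step among the measured compounds, a step that the two limits leave unreadable from compound 2 to compound 3, cannot be read because both ends are limits, so it gives no size to lean on.

Compound 4 `O=C(OC1CCC(CN2CCN(c3cc(=O)c4cc(C(F)(F)F)cc([N+](=O)[O-])c4s3)CC2)CC1)c1cccc(F)c1` differs from compound 1 by ((3-fluorophenyl)carbonyl)oxy in place of methanesulfonamido on a saturated ring carbon. The group that enters places compound 4 alongside compounds 2 and 3, both of which carry an aromatic ester on the same saturated ring carbon and both of which reached only the limit. Going by the values given here, no measured step bears directly on this change, so the expectation rests on that resemblance alone.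

Compound 4 is therefore expected to land near the limit, at about 70 ug/mL, within 40 ug/mL to 130 ug/mL. The step of a 1.4-fold higher number from compound 1 to compound 4 (0.16 log units; within the scatter) is estimated to be toward weaker inhibition, though it may well not exceed the scatter, and the assay may again report only a limit.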

Compound 4, half-maximal inhibitory concentration: > 64 ug/mL
Compound 4: a limit, no number; the forecaster's own chance of this, stated with the estimate: 60%; the middle value does not contradict the limit.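

For the compounds shown here, compound 4 gives the first direct reading of an aromatic ester against methanesulfonamido on this saturated ring carbon: in this assay, ((3-fluorophenyl)carbonyl)oxy in place of methanesulfonamido gives an at least 1.3-fold higher number from compound 1 to compound 4 (0.12 log units; that floor lies within the scatter), so this floor alone does not establish a change beyond the scatter, and the true size of the step stays unknown. Compound 4 also shows that an ester bearing a 3-fluorophenyl ring joins those bearing naphthalen-2-yl and 3-(trifluoromethyl)phenyl, and all three esters now report a limit rather than a number: the limit of > 64 ug/mL in this assay, at which 3 of the 4 values shown sit. The steps among compounds 2, 3 and 4 cannot be read, since both ends of each are limits, so these aromatic groups cannot be ranked against one another in this assay.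

The compounds shown leave open how far the three esters lie past the limit, and whether the ester link or its aromatic ring carries the step from compound 1. A simple acetyl ester or an amine on the same saturated ring carbon would help to separate those two parts.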